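A few compounds are considered here, and "the series" means these few. Any claim that something is new, unique, unknown or untested is made for them only; others in the source may bear on it.

Of the compounds shown here, two have so far been measured in a functional assay on U-251 cells (Homo sapiens) for inhibition, read by sulforhodamine B assay, with a stated time of 48 h, tested at 1 uM; on this read-out lower numbers stand for a stronger effect and higher numbers for a weaker effect at the one concentration tested. Compound 1, `O=C(Nc1cccc(-n2cc(-c3ccncc3)c(-c3cc(O)cc(Cl)c3)n2)c1)Nc1ccc(Cl)c(Cl)c1`, gives 74% in this assay. Compound 2, `COc1cc(Cl)cc(-c2nn(-c3cccc(NC(=O)Nc4ccc(Cl)c(C(F)(F)F)c4)c3)cc2-c2ccncc2)c1`, gives 43% in this assay, the lower of the two numbers, and the gap to compound 1 lies beyond the usual scatter of repeated measurements. Compound 1 and compound 2 differ from each other in more than one place, so what each of those changes contributes on its own is not known.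

Compound 3, `COc1cc(Cl)cc(-c2nn(-c3cccc(NC(=O)Nc4ccc(Cl)c(Cl)c4)c3)cc2-c2ccncc2)c1`, has not yet been measured. It is made from compound 2 by a single change: chloro in place of trifluoromethyl on an aromatic carbon. Compound 1 carries the same 3,4-dichlorophenyl group as compound 3 but differs from compound 2 in another place as well, so its higher number does not isolate this one change. Working only from those two numbers and the change itself, the step from compound 2 to compound 3 is expected to be a number 14 percentage points higher from compound 2 to compound 3 (beyond the scatter), a modest rise that may not pass the scatter. Compound 3 is therefore estimated at 57%, within a range from 35% to 80%.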

Compound 3, a percentage reported as activity, at one concentration (the size of the read-out at that concentration, not a potency): 71%
Compound 3: the middle estimate sits 14 percentage points below what was measured; the range from low to high includes it.
By their numbers in this assay, from the lowest: compound 2; then compounds 3 and 1 (each within the scatter of the next).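

Swapping trifluoromethyl for chloro on this aromatic carbon, ortho to a chloro group and meta to a large group, can now be read on its own: in this assay the swap gives a number 28 percentage points higher from compound 2 to compound 3 (beyond the scatter), which here means a weaker effect at the one concentration tested. Compound 3 also gives the first clean reading of the other place that separates the earlier compounds, since methyl in place of hydrogen on the oxygen gives a number 3 percentage points lower from compound 1 to compound 3 (within the scatter) and stays within the scatter, so among these three compounds only the change on the aromatic carbon produces a step beyond the scatter. Nothing available explains why trifluoromethyl and chloro differ in this way.

Going by these compounds, only these two groups are compared at this carbon, so it remains open whether a methyl, a methoxy or a nitrile there would read closer to compound 2 or to compound 3. On these data alone, it is also open whether the same order would hold at other concentrations, as each number here is a single reading at one concentration and says nothing of potency.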